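Adding Iodine to a Compound: Expecting No Change

The source may report more compounds than this note shows. Statements on the series, on what has been measured and on what is new or still open speak of the compounds shown alone.

Of the compounds shown here, two sharing one core have been measured in a functional assay on CCRF S-180 cells (Mus musculus) for cytotoxicity, with a stated time of 42 h, tested at 400 uM; a lower number here means less inhibition, a higher number more inhibition at the concentration tested (going by the name of the read-out). Compound 1, `N#C[C@H]1O[C@@H](n2cc(I)c(O)nc2=O)C[C@@H]1O`, carries an iodo group and a nitrile on that core; in this assay compound 1 gives 0%. Compound 2, `NC(=O)[C@H]1O[C@@H](n2ccc(O)nc2=O)C[C@@H]1O`, carries an amide in place of the nitrile and has a hydrogen where compound 1 has the iodo group; in this assay compound 2 gives 0%. Compound 2 thus stands level with compound 1 at the digits shown, the two values lying within the scatter of one another, and neither compound shows any inhibition at the concentration tested.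

Compound 3, `NC(=O)[C@H]1O[C@@H](n2cc(I)c(O)nc2=O)C[C@@H]1O`, has not yet been measured. It differs from compound 2 by iodo in place of hydrogen on an aromatic carbon. Compound 1 already carries the iodo group and gives 0% in this assay, while compound 2 gives 0%, so no step beyond the scatter is expected, no change at the digits printed from compound 2 to compound 3 (within the scatter). Compound 3 is therefore expected to give 0% in this assay, with a range from 0% to 10%.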

Compound 3, a percentage reported as inhibition, at one concentration (the size of the read-out at that concentration, not a potency): 0%
Compound 3: middle estimate and measured number agree at the digits printed, and the stated range covers the measured number.
By their numbers in this assay, from the lowest: compounds 1, 2 and 3 (each within the scatter of the next).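

Compounds 1 and 2 differ in two places at once, but compound 3 allows each place to be read alone, and in this assay putting iodo in place of hydrogen on the aromatic carbon ortho to a hydroxy group, with the amide kept, gives no change at the digits printed from compound 2 to compound 3 (within the scatter). With the iodo group kept, carbamoyl in place of cyano on a saturated ring carbon gives no change at the digits printed from compound 1 to compound 3 (within the scatter), so neither single change produces a measurable step at the concentration tested. No measured data here offer an explanation for these results.

All three compounds sit at the same reading of no inhibition, which leaves open whether either place can alter the read-out in a compound that shows some inhibition to begin with. As far as these compounds go, it also remains open whether a different group would give any inhibition in this assay, such as an amine on the aromatic carbon or a carboxylic acid on the saturated ring carbon.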